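Moving the Nitrogen Within the Pyridylmethyl Group

The compounds below may be only part of what the source reports. "The series", "measured", "known", "first", "only" and "open" are said of these compounds alone.

Compound 1 `COCCn1c(SCc2cc([N+](=O)[O-])ccc2OC)nc2cc(NC(=O)NC(C)(C)C)ccc21` gives 280 nM in an assay on isolated protein for inhibition of Gonadotropin-releasing hormone receptor (Rattus norvegicus); a lower number here means a stronger inhibitor, a higher number a weaker inhibitor.
Compound 2 `COc1ccc([N+](=O)[O-])cc1CSc1nc2cc(NC(=O)NC(C)(C)C)ccc2n1Cc1ccccc1` gives 160 nM.
Compound 3 `COc1ccc([N+](=O)[O-])cc1CSc1nc2cc(NC(=O)NC(C)(C)C)ccc2n1Cc1ccccn1` gives 670 nM.

Compound 3 stands highest of the three and is the weakest inhibitor here, as a 2.4-fold higher number from compound 1 to compound 3 (0.38 log units; beyond the scatter) and a 4.2-fold higher number from compound 2 to compound 3 (0.62 log units; beyond the scatter) both lie beyond the scatter. Compound 4 `COc1ccc([N+](=O)[O-])cc1CSc1nc2cc(NC(=O)NC(C)(C)C)ccc2n1Cc1cccnc1` differs from it only at the saturated chain carbon bound to the aromatic nitrogen: pyridin-3-yl in place of pyridin-2-yl on a saturated chain carbon bound to an aromatic nitrogen. For the measured compounds named here, no measured step swaps one pyridyl isomer for another. The nearest guides are a 4.2-fold higher number from compound 2 to compound 3 (0.62 log units; beyond the scatter), a modest change, and a 1.8-fold lower number from compound 1 to compound 2 (0.24 log units; within the scatter), which stayed within the scatter. With nothing directly comparable, only a small step in this assay is expected. Compound 4 is therefore estimated at 400 nM, within 150 nM to 1200 nM, and the expected step is a 1.7-fold lower number from compound 3 to compound 4 (0.22 log units; within the scatter).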

Compound 4, half-maximal inhibitory concentration: 150 nM
Compound 4: middle estimate off by 2.7-fold (0.43 log units), on the high side; the measured number falls inside the stated range.
By their numbers in this assay, from the lowest: compounds 4, 2 and 1 (each within the scatter of the next); then compound 3.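

Moving the ring nitrogen alone matters at this position: in this assay, pyridin-3-yl in place of pyridin-2-yl gives a 4.5-fold lower number from compound 3 to compound 4 (0.65 log units; beyond the scatter). The pyridin-3-yl group cannot be told apart from phenyl, with a 1.1-fold lower number from compound 2 to compound 4 (0.03 log units; within the scatter), or from methoxymethyl, with a 1.9-fold lower number from compound 1 to compound 4 (0.27 log units; within the scatter), so among these compounds the weaker result belongs to pyridin-2-yl alone, not to pyridine rings in general. Nothing given here explains why the nitrogen's place matters. On these data alone, how pyridin-4-yl would compare remains open, as does the effect of an amine or a carboxylic acid on the ring.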